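The source may report more compounds than this note shows. Statements on the series, on what has been measured and on what is new or still open speak of the compounds shown alone.

Three compounds that share one core and differ only in the group on a saturated chain carbon, two bonds along the chain from an oxygen on an aromatic ring, have been run in an ADME assay on microsomes from liver (Rattus norvegicus) for metabolic stability, read by LC-MS, tested at 0.5 uM; a lower number here means that the compound disappears faster, a higher number that the compound lasts longer. Compound 1 `Cc1cc(CCOc2ccc(-c3c(C)nc(C)c([C@H](OC(C)(C)C)C(=O)O)c3N3CCC(C)(C)CC3)cc2)ccc1F` carries a 4-fluoro-3-methylphenyl group there, compound 2 `Cc1nc(C)c([C@H](OC(C)(C)C)C(=O)O)c(N2CCC(C)(C)CC2)c1-c1ccc(OCCCc2ccc(F)cc2)cc1` a 4-fluorobenzyl group, and compound 3 `Cc1ccc(CCOc2ccc(-c3c(C)nc(C)c([C@H](OC(C)(C)C)C(=O)O)c3N3CCC(C)(C)CC3)cc2)s1` a 5-methylthiophen-2-yl group. In this assay compound 1 reaches only the limit of the assay, > 2 h. Compound 2 likewise gives only the limit > 2 h. Compound 3 too gives only the limit > 2 h. Because (the limit of > 2 h in this assay, at which 3 of the 3 values shown sit), the steps a step that the two limits leave unreadable from compound 1 to compound 2, a step that the two limits leave unreadable from compound 1 to compound 3 and a step that the two limits leave unreadable from compound 2 to compound 3 cannot be sized, and compound 3 stands at the same limit as the other two.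

Compound 4 `Cc1nc(C)c(CCOc2ccc(-c3c(C)nc(C)c([C@H](OC(C)(C)C)C(=O)O)c3N3CCC(C)(C)CC3)cc2)s1` is not yet measured. It differs from compound 3 by 2,4-dimethyl-1,3-thiazol-5-yl in place of 5-methylthiophen-2-yl on a saturated chain carbon, two bonds along the chain from an oxygen on an aromatic ring. Among the measured compounds shown here, none of the measured steps sizes a change of this kind. The step that the limit leaves unreadable from compound 3 to compound 4 is therefore expected to be nil beyond the scatter. In this assay compound 4 is expected to sit at the same limit, with an estimated half-life of 2.5 h, between 1 h and 6 h.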

Compound 4, half-life: > 2 h
Compound 4: no number, only a limit (the forecaster's own chance of this, stated with the estimate: 75%); the middle value lies beyond the limit too.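

No step involving compound 4 can be read, since compound 4 gives only a limit, as do compound 1, compound 2 and compound 3: the limit of > 2 h in this assay, at which 4 of the 4 values shown sit.

The compounds shown leave open what the half-life of each of the four actually is, and whether these groups differ from one another at all.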